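This account rests on a few compounds, and the source may have more. Where it says the series, first, only, none or still open, it means among the compounds named here.

Two members of the series, compound 1 `Cc1ccc2occ(C3N=C(c4ccccc4)SS3)c(=O)c2c1` and compound 2 `O=c1c(C2N=C(c3ccccc3)SS2)coc2cc(Cl)ccc12`, have been run in a functional assay on HEp-2 cells (Homo sapiens) for inhibition, read by sulforhodamine B assay, with a stated time of 48 h; a lower number here means a stronger inhibitor, a higher number a weaker inhibitor. In this assay compound 1 gives only a limit, > 100000 nM. In this assay compound 2 likewise gives only a limit, > 100000 nM. Compound 2 therefore stands at the limit of > 100000 nM in this assay, at which 2 of the 2 values shown sit. Compound 3 `O=c1c(C2N=C(c3ccccc3)SS2)coc2ccccc12` differs from compound 2 by hydrogen in place of chloro on an aromatic carbon. With both measured values at the limit, no step beyond the scatter is expected, and compound 3 is expected to stay at the limit. The estimated step is a step that the limit leaves unreadable from compound 2 to compound 3. The expected value for compound 3 in this assay is 150000 nM, in the range 50000 nM to 500000 nM.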

Compound 3, half-maximal inhibitory concentration: > 100000 nM
Compound 3: a limit, no number; the forecaster's own chance of this, stated with the estimate: 85%; the middle value lies beyond the limit too.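

No step can be read among compound 1, compound 2 and compound 3 in this assay, where each value is a limit and not a number: the limit of > 100000 nM in this assay, at which 3 of the 3 values shown sit.

On these data alone, whether hydrogen in place of chloro or methyl on an aromatic carbon changes inhibition at all remains open.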